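Swapping a Dimethoxyphenyl for a Methyl Ester Phenyl

This account rests on a few compounds, and the source may have more. Where it says the series, first, only, none or still open, it means among the compounds named here.

Measured so far:
- compound 1, `COc1ccc(/C(=N/OCC(=O)O)c2cccc3ccccc23)c(OC)c1OC`: in a functional assay on A549 cells (Homo sapiens) for inhibition, read by sulforhodamine B assay, with a stated time of 48 h (a higher number here means a weaker inhibitor, a lower number a stronger inhibitor), compound 1 gives 17200 nM.
- compound 2, `COc1cc(COC(c2ccc(OC)c(OC)c2OC)c2cccc3ccccc23)cc(OC)c1`: in this assay compound 2 gives 17500 nM.

Both compounds share the same central unit, a trimethoxyphenyl and a naphthyl held on one saturated carbon; they differ in what else hangs from that carbon. In this assay compound 2 and compound 1 give numbers that sit level with each other, the gap between them lying inside the scatter of repeated measurements, so neither can be called the stronger of the two. Both are weak inhibitors on this scale.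

Compound 3, `COC(=O)c1ccc(COC(c2ccc(OC)c(OC)c2OC)c2cccc3ccccc23)cc1`, has not yet been measured. It differs from compound 2 in one place: 4-(methoxycarbonyl)phenyl in place of 3,5-dimethoxyphenyl on a saturated chain carbon bound to an oxygen on a saturated carbon. Among the measured compounds shown here, no comparison between measured compounds covers a change of this kind, so there is nothing to set a direction from. The step from compound 2 to compound 3 in this assay is expected to be small, a 1.1-fold higher number from compound 2 to compound 3 (0.06 log units; within the scatter), probably not beyond the scatter. Compound 3 is therefore estimated at 20000 nM, within a range from 6000 nM to 60000 nM.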

Compound 3, half-maximal inhibitory concentration: 12000 nM
Compound 3: the middle estimate sits 1.7-fold (0.22 log units) above what was measured; the measured number falls inside the stated range.
By their numbers in this assay, from the lowest: compounds 3, 1 and 2 (each within the scatter of the next).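

In this assay, the change of 3,5-dimethoxyphenyl to 4-(methoxycarbonyl)phenyl on a saturated chain carbon bound to an oxygen on a saturated carbon gives a 1.5-fold lower number from compound 2 to compound 3 (0.16 log units; within the scatter) and so cannot be told apart from no change at all. Among the compounds shown here, this is the first comparison at this position, and it shows that two differently substituted phenyl groups, matched in heavy atoms and hydrogen-bond acceptors, give numbers that sit level even though the entering group brings a double bond outside the ring. No separate measurement bears on this result.

One swap of this kind cannot show whether this position is insensitive in general, since both groups are substituted benzene rings of the same size. From the compounds shown here alone, whether a primary amide in place of the methyl ester, a pyridine ring in place of the benzene ring, or a longer chain in place of the benzyl group would move the number beyond the scatter remains open.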